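The source may report more compounds than this note shows. Statements on the series, on what has been measured and on what is new or still open speak of the compounds shown alone.

Measured compounds:
- compound 1 `O=C(Nc1ccc(Sc2nc3ccccc3s2)c(Cl)c1)c1cc(Br)cc(Br)c1`; in an assay for inhibition of HSP60/HSP10 (Homo sapiens), with a stated time of 60 min (on this read-out lower numbers stand for stronger inhibition and higher numbers for weaker inhibition), compound 1 gives > 100000 nM, which is a limit of the assay.
- compound 2 `COc1ccccc1C(=O)Nc1ccc(Sc2nc3ccccc3s2)cc1`; in this assay compound 2 gives > 100000 nM, again only a limit.
- compound 3 `COc1c(Br)cc(Br)cc1C(=O)Nc1cccc(Cl)c1`; in this assay compound 3 gives > 100000 nM, also a limit.

Compound 2 thus stands at the limit of > 100000 nM in this assay, at which 3 of the 3 values shown sit, and no measured value in the set separates it from the other two. Compound 4 `O=C(Nc1ccc(Sc2nc3ccccc3s2)cc1)c1cccc(Br)c1O` carries 3-bromo-2-hydroxyphenyl in place of 2-methoxyphenyl on a carbonyl carbon. Within the data shown here, no measured step of this kind exists in the set, so the expected change a number no higher from compound 2 to compound 4 (the limit leaves the size open) is taken as none beyond the scatter. For compound 4 the estimate in this assay is 100000 nM, with a range from 30000 nM to 300000 nM, and most probably again a limit.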

Compound 4, half-maximal inhibitory concentration: 26000 nM
Beside the measured number, compound 4's estimate is 3.8-fold (0.59 log units) above it; measured number outside the range, below it.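

In this assay, placing 3-bromo-2-hydroxyphenyl instead of 2-methoxyphenyl on the carbonyl carbon gives an at least 3.8-fold lower number from compound 2 to compound 4 (0.58 log units; beyond the scatter), the first move off the limit in this set, so this position can change the read-out. Compound 2 gives > 100000 nM, which is a limit, so the step has a lower bound and no fixed size. The other compounds offer no further reference point: the limit of > 100000 nM in this assay, at which 3 of the 4 values shown sit.

The change combines bromine with hydroxy for methoxy, and the compounds shown do not separate these two parts. On these data alone, whether an amine or a carboxylic acid in place of the hydroxy group would keep the lower number also stays open.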